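Three limits and one benzoyl swap on a shared amide

The compounds below may be only part of what the source reports. "The series", "measured", "known", "first", "only" and "open" are said of these compounds alone.

Compound 1 `CC(=O)Nc1cc(NC(=O)Nc2ccc3c(c2)OCCO3)ccc1C` gives in a functional assay on A375P cells (Homo sapiens) for antiproliferative activity (a lower number here means a stronger inhibitor, a higher number a weaker inhibitor), only the limit > 30000 nM. Compound 2 `Cc1ccc(NC(=O)Nc2ccc3c(c2)OCCO3)cc1NC(=O)c1ccccc1` gives in this assay only the limit > 30000 nM. Compound 3 `CC(=O)Nc1cc(NC(=O)c2cc(C(F)(F)F)cc(C(F)(F)F)c2)ccc1C` gives in this assay only the limit > 30000 nM.

Compound 1 and compound 2 share one core and differ by phenyl in place of methyl on a carbonyl carbon. The step that the two limits leave unreadable from compound 1 to compound 2 cannot be sized, because both values sit at the limit of > 30000 nM in this assay, at which 3 of the 3 values shown sit. Compound 3 carries a different core; the difference between the two cores is not broken down here, and compound 3, like the other two, reaches only a limit in this assay.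

Compound 4 `Cc1ccc(NC(=O)c2cc(C(F)(F)F)cc(C(F)(F)F)c2)cc1NC(=O)c1ccccc1` has not yet been measured. Going by the values given here, it differs from compound 3 by phenyl in place of methyl on a carbonyl carbon, which is the same change, at the same kind of place, as the one made from compound 1 to compound 2. That earlier instance of the change left no readable step, and every value shown so far is a limit, so there is nothing here that points to a gain in potency from this swap.

Compound 4 is therefore expected to remain weak in this assay, with an estimated value of 30000 nM, most likely between 8000 nM and 100000 nM. The expected step of a number no higher from compound 3 to compound 4 (the limit leaves the size open) rests on compound 3 sitting at the limit of > 30000 nM in this assay, at which 3 of the 3 values shown sit, and on the unreadable step that the two limits leave unreadable from compound 1 to compound 2, with a real chance that compound 4 also returns only a limit.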

Compound 4, half-maximal inhibitory concentration: > 30000 nM
Compound 4: no number, only a limit; the forecaster's own chance of this, stated with the estimate: 65%; the middle value sits exactly at the limit.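

No step can be read from compound 3 to compound 4 in this assay, because both compounds return only a limit, as compound 1 and compound 2 did: the limit of > 30000 nM in this assay, at which 4 of the 4 values shown sit.

The compounds shown leave open how potent any of them actually is in this assay, and whether phenyl in place of methyl on a carbonyl carbon changes potency at all.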